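The source may hold more compounds than are shown below. What is called first, only, known or untested is meant among the compounds shown, and "the series" means these compounds.

In a functional assay on MCF7 cells (Homo sapiens) for inhibition, read by MTT assay, with a stated time of 96 h (a higher number here means a weaker inhibitor of growth, a lower number a stronger inhibitor of growth), compound 2 (`Cc1cc(C(=O)NCCCCCCS)[nH]n1`) gives > 50000 nM, which is a limit and not a number. Compound 3 (`O=C(CCCCCCS)Nc1ccccc1`) also gives a limit, > 50000 nM. Only compound 1 (`O=C(OCc1ccccc1)SCCCCCCNC(=O)c1cc(-c2ccncc2)n[nH]1`) reaches a number, 8370 nM. It bears a six-membered aromatic ring on the corresponding carbon, and its sulfur carries a benzyloxycarbonyl group. Compound 4 (`O=C(NCCCCCCS)c1cc(-c2cnccn2)n[nH]1`) follows from compound 2 by pyrazin-2-yl in place of methyl on an aromatic carbon, with pyrazin-2-yl in place of methyl on an aromatic carbon. Within the data shown here, no measured step isolates this change. On the evidence of compound 1 at 8370 nM, stronger growth inhibition is expected, though its size is uncertain. The expected change is an at least 4.1-fold lower number from compound 2 to compound 4 (0.61 log units; beyond the scatter). Compound 4 is estimated at 12000 nM, within an expected range of 3000 nM to 45000 nM.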

Compound 4, concentration for 50% growth inhibition: > 50000 nM
Compound 4 was reported as a limit; the forecaster's own chance of this, stated with the estimate: 25%; middle value at least 4.1-fold (0.61 log units) away from the limit.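

No step can be read from compound 2 to compound 4, since each gives only a limit: the limit of > 50000 nM in this assay, at which 3 of the 4 values shown sit.

As far as these compounds go, whether pyrazin-2-yl in place of methyl on an aromatic carbon alters growth inhibition at all stays open.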